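The compounds below may be only part of what the source reports. "The series", "measured", "known", "first", "only" and "open" are said of these compounds alone.

Measured compounds:
compound 1, `COc1ccc(-c2cnc3nc(N)nc(N4CCN(C(=O)NCc5ccccc5)CC4)c3n2)cc1OC`: 18 nM
compound 2, `COc1ccc(-c2cnc3nc(N)nc(N4CCN(C(=O)Nc5cccc(C)c5)CC4)c3n2)cc1OC`: 7 nM
compound 3, `COc1ccc(-c2cnc3nc(N)nc(N4CCN(Cc5ccc(C(C)(C)C)cc5)CC4)c3n2)cc1OC`: not yet measured

In a functional assay on cells (T-cell, Homo sapiens) for inhibition (on this read-out higher numbers stand for weaker inhibition and lower numbers for stronger inhibition), compound 2 gives 7 nM, the lowest of the two numbers, and its nearest neighbour is compound 1, which gives 18 nM. Among the compounds with values here, the one measured step is a 2.6-fold lower number from compound 1 to compound 2 (0.41 log units; beyond the scatter), which exchanged the group on the outer nitrogen of the carbamoyl while the carbamoyl itself stayed in place.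

Compound 3 differs from compound 2 as follows: 4-(tert-butyl)benzyl in place of (3-methylphenyl)carbamoyl on an amine nitrogen in a ring. Within the data shown here, both measured compounds carry a carbamoyl on the ring nitrogen, so no measured step bears on its removal; the step from compound 1 to compound 2 was modest and touched only the outer group. The change here is larger than that, removing the carbamoyl altogether, and the data give no comparison for it, so the estimate is wide.

For compound 3 in this assay a step of a 5.7-fold higher number from compound 2 to compound 3 (0.76 log units; beyond the scatter) toward weaker inhibition is expected, which is plainly an estimate rather than a measured step. Compound 3 is therefore estimated at 40 nM, within a range of 7 nM to 250 nM.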

Compound 3, half-maximal inhibitory concentration: 4300 nM
Compound 3: middle estimate off by 110-fold (2.03 log units), on the low side, and the stated range ends below it.
By their numbers in this assay, from the lowest: compound 2; then compound 1; then compound 3.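

In this assay the step at this amine nitrogen in a ring is of a different order from the one seen so far: a 610-fold higher number from compound 2 to compound 3 (2.79 log units; beyond the scatter) and a 240-fold higher number from compound 1 to compound 3 (2.38 log units; beyond the scatter) are both large, whereas a 2.6-fold lower number from compound 1 to compound 2 (0.41 log units; beyond the scatter) is modest. The two compounds that keep the carbamoyl therefore lie close together compared with compound 3, so exchanging the whole carbamoyl-bearing group for 4-(tert-butyl)benzyl matters far more here than exchanging the outer group alone, at least among these three compounds. The exchange also leaves the ring nitrogen with a substituent that counts no hydrogen-bond donor or acceptor, but no measurement on hand accounts for the loss of inhibition.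

The change removed the carbamoyl and brought in the tert-butyl in one move, so the compounds shown do not separate the contribution of the two. As far as these compounds go, how a plain benzyl on the ring nitrogen, or a 4-(tert-butyl)benzyl kept on the outer nitrogen of the carbamoyl, would read in this assay remains open.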